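A few compounds are considered here, and "the series" means these few. Any claim that something is new, unique, unknown or untested is made for them only; others in the source may bear on it.

In an ADME assay on cells (Hepatocyte, Rattus norvegicus) for pharmacokinetics, read by LC-MS, with a stated time of 90 min, tested at 1 uM (on this read-out higher numbers stand for fast clearance and lower numbers for slow clearance), two compounds have been measured so far:

- compound 1 `Nc1nc(-c2nn(Cc3ccccc3F)c3ncccc23)nc(N)c1NC(=O)OC1CCC1`: 23.3 mL/min/kg
- compound 2 `Nc1nc(-c2nn(Cc3ccccc3F)c3ncccc23)nc(N)c1NC(=O)OCC(F)(F)F`: 35 mL/min/kg

For the measured compounds named here, compound 2 stands within the usual scatter of compound 1, the only other measured compound. Compound 3 `Nc1nc(-c2nn(Cc3ccccc3F)c3ncccc23)nc(N)c1NC(=O)OCC1CC1` differs from compound 2 as follows: cyclopropyl in place of trifluoromethyl on a saturated chain carbon bound to an oxygen next to a carbonyl group. In words, 2,2,2-trifluoroethyl becomes cyclopropylmethyl. Going by the values given here, the only measured step that bears on this is a 1.5-fold higher number from compound 1 to compound 2 (0.18 log units; within the scatter), which put 2,2,2-trifluoroethyl in place of cyclobutyl. With just this one small step as a guide, no change beyond the scatter is expected in this assay. The expected step is a 1.3-fold lower number from compound 2 to compound 3 (0.10 log units; within the scatter). For compound 3 the estimate is 28 mL/min/kg, with an expected range of 15 mL/min/kg to 50 mL/min/kg.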

Compound 3, clearance: 23.3 mL/min/kg
Compound 3: middle estimate off by 1.2-fold (0.08 log units), on the high side, and the stated range covers the measured number.
By their numbers in this assay, from the lowest: compounds 1, 3 and 2 (each within the scatter of the next).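

In this assay, cyclopropyl in place of trifluoromethyl on a saturated chain carbon bound to an oxygen next to a carbonyl group gives a 1.5-fold lower number from compound 2 to compound 3 (0.18 log units; within the scatter), while cyclopropylmethyl in place of cyclobutyl gives no change at the digits printed from compound 1 to compound 3 (within the scatter). Cyclobutyl, 2,2,2-trifluoroethyl and cyclopropylmethyl thus all read alike at this position, whether or not the group carries fluorine or a three-membered ring. No supporting measurement is available to explain this result. Still open, going by these compounds, is whether a group holding an amine or a carboxylic acid, or a longer chain, would stay within this narrow band. The compounds shown cover only small groups on this oxygen, so larger changes here remain untested by these numbers.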